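This account rests on a few compounds, and the source may have more. Where it says the series, first, only, none or still open, it means among the compounds named here.

In a functional assay on PC-3 cells (Homo sapiens) for inhibition, read by sulforhodamine B assay, with a stated time of 72 h (on this read-out lower numbers stand for stronger inhibition and higher numbers for weaker inhibition), three amides of one shared core have been measured. Compound 1 (`CC1CCN(C(=O)c2c(N)sc(-c3ccc(Cl)cc3)c2-c2ccc(Cl)cc2)CC1`) gives 5750 nM, compound 2 (`Nc1sc(-c2ccc(Cl)cc2)c(-c2ccc(Cl)cc2)c1C(=O)NC1CCC1`) gives 24800 nM, and compound 3 (`Nc1sc(-c2ccc(Cl)cc2)c(-c2ccc(Cl)cc2)c1C(=O)NC1CCC(O)CC1`) gives 5670 nM. Compound 3 therefore stands level with compound 1, a 1.0-fold lower number from compound 1 to compound 3 (0.01 log units; within the scatter), and clear of the third compound, a 4.4-fold lower number from compound 2 to compound 3 (0.64 log units; beyond the scatter).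

Compound 4 (`Nc1sc(-c2ccc(Cl)cc2)c(-c2ccc(Cl)cc2)c1C(=O)N1CCC(=O)CC1=O`) carries 2,4-dioxopiperidin-1-yl in place of (4-hydroxycyclohexyl)amino on a carbonyl carbon. Among the compounds with values here, no measured compound carries this group, so the evidence is indirect. Of the three groups tested at this place, 4-methylpiperidin-1-yl and (4-hydroxycyclohexyl)amino read alike, while cyclobutylamino departs, a 4.3-fold higher number from compound 1 to compound 2 (0.63 log units; beyond the scatter). The steps at this place thus range from none beyond the scatter to modest, and a modest rise at most is expected in this assay. The estimated change is a 1.4-fold higher number from compound 3 to compound 4 (0.15 log units; within the scatter). For compound 4 the expected value is 8000 nM, with an estimated range of 2500 nM to 25000 nM.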

Compound 4, half-maximal inhibitory concentration: 9230 nM
For compound 4 the middle estimate is 1.2-fold (0.06 log units) below the measured one, and the stated range covers the measured number.
By their numbers in this assay, from the lowest: compounds 3, 1 and 4 (each within the scatter of the next); then compound 2.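

In this assay, 2,4-dioxopiperidin-1-yl, with no hydrogen-bond donors, reads alike to the donor-bearing (4-hydroxycyclohexyl)amino (a 1.6-fold higher number from compound 3 to compound 4 (0.21 log units; within the scatter)) and to 4-methylpiperidin-1-yl (a 1.6-fold higher number from compound 1 to compound 4 (0.21 log units; within the scatter)), so two double bonds outside aromatic rings and a changed hydrogen-bond count on this carbonyl carbon do not separate these compounds. The step from the cyclobutylamino amide (a 2.7-fold lower number from compound 2 to compound 4 (0.43 log units; beyond the scatter)) leaves compound 2 as the only one of the four set apart from the others at this place. No measurement shown here accounts for these numbers.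

Going by these compounds, whether an amine or a carboxylic acid on the six-membered ring would move the number beyond the scatter remains open. So does the outcome for an open-chain amide, such as diethylamino, on this carbonyl carbon.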